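The source may report more compounds than this note shows. Statements on the series, on what has been measured and on what is new or still open speak of the compounds shown alone.

Compound 1 (`COc1ccc(C(=O)/C=C\Nc2ccc(-c3nc4cc(OC)c(OC)c(OC)c4s3)cc2C)cc1[N+](=O)[O-]`): 23400 nM
Compound 2 (`COc1ccc2nc(-c3ccc(N/C=C\C(=O)c4ccc(OC)c(O)c4)cc3)sc2c1`): 21900 nM

In a functional assay on MIA PaCa-2 cells (Homo sapiens) for antiproliferative activity, read by sulforhodamine B assay, with a stated time of 48 h (a lower number here means a stronger inhibitor, a higher number a weaker inhibitor), compound 2, at 21900 nM, lies within the scatter of compound 1, so the two cannot be ranked. Compound 3 (`COc1ccc2nc(-c3ccc(N/C=C\C(=O)c4ccc(OC)c(F)c4)cc3)sc2c1`) differs from compound 2 at one place: fluoro in place of hydroxy on an aromatic carbon, which is fluoro in place of hydroxy on an aromatic carbon, ortho to a methoxy group. Among the compounds with values here, no measured pair tests this swap, so no step beyond the scatter is expected, in either direction. The expected change, a 1.2-fold lower number from compound 2 to compound 3 (0.09 log units; within the scatter), is small. For compound 3 the estimated value is 18000 nM, with 6000 nM to 50000 nM as the expected range.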

Compound 3, half-maximal inhibitory concentration: 1300 nM
Estimate against measurement, compound 3: 14-fold (1.14 log units) above; measured number outside the range, below it.
By their numbers in this assay, from the lowest: compound 3; then compounds 2 and 1 (each within the scatter of the next).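

At this place on the ring, ortho to a methoxy group, one atom matters: in this assay, fluoro in place of hydroxy gives a 17-fold lower number from compound 2 to compound 3 (1.23 log units; beyond the scatter) in a single swap. The change also removes the hydrogen-bond donor and acceptor counted for hydroxy, but this one pair cannot show which difference counts, and no measurement here explains the step.

On these data alone, whether the lower number comes from having fluoro or simply from losing hydroxy remains open. Compounds carrying hydrogen, chloro or an amine at this place would help separate the two.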